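Hydroxy-nitrophenyl isomers in a growth inhibition series

The source may hold more compounds than are shown below. What is called first, only, known or untested is meant among the compounds shown, and "the series" means these compounds.

Of the compounds shown here, two have been measured so far in a functional assay on DU-145 cells (Homo sapiens) for inhibition, read by trypan blue exclusion, with a stated time of 96 h; a lower number here means a stronger inhibitor of growth, a higher number a weaker inhibitor of growth. Compound 1 `O=C(/C(=C\c1ccc(O)c([N+](=O)[O-])c1)S(=O)(=O)Cc1ccc(Br)cc1)c1c(F)c(F)c(F)c(F)c1F` gives 50000 nM. Compound 2 `O=C(/C(=C\c1ccc([N+](=O)[O-])c(O)c1)Sc1ccc(Br)cc1)c1c(F)c(F)c(F)c(F)c1F` gives 1000 nM, the lower of the two numbers, and the gap between them lies well beyond the usual scatter.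

The next compound is compound 3 `O=C(/C(=C\c1ccc(O)c([N+](=O)[O-])c1)Sc1ccc(Br)cc1)c1c(F)c(F)c(F)c(F)c1F`, which has the same atoms as compound 2, joined differently. It carries 4-hydroxy-3-nitrophenyl in place of 3-hydroxy-4-nitrophenyl on a double-bonded chain carbon bound to a double-bonded chain carbon.

Going by the values given here, no pair of measured compounds differs in one place only, so the series offers no direct precedent for this swap. Among the compounds with values here, compound 1 carries the entering 4-hydroxy-3-nitrophenyl and gives 50000 nM, but it also differs from compound 3 elsewhere, so that value sets no size for the step. A modest change towards a weaker inhibitor of growth is expected, most likely not beyond the scatter: the estimated step is a 1.5-fold higher number from compound 2 to compound 3 (0.18 log units; within the scatter). For compound 3 the expected value is 1500 nM, with an estimated range of 300 nM to 8000 nM.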

Compound 3, concentration for 50% growth inhibition: 1000 nM
The estimate for compound 3 lay 1.5-fold (0.18 log units) above the measured number; the range from low to high includes it.
By their numbers in this assay, from the lowest: compounds 2 and 3 (each within the scatter of the next); then compound 1.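

In this assay, 4-hydroxy-3-nitrophenyl in place of 3-hydroxy-4-nitrophenyl on a double-bonded chain carbon bound to a double-bonded chain carbon gives no change at the digits printed from compound 2 to compound 3 (within the scatter) and so, at this place, the two isomers are not told apart by this read-out. With 4-hydroxy-3-nitrophenyl held constant, (4-bromophenyl)sulfanyl in place of (4-bromobenzyl)sulfonyl on a double-bonded chain carbon bound to a carbonyl carbon and a double-bonded chain carbon gives a 50-fold lower number from compound 1 to compound 3 (1.70 log units; beyond the scatter) and this is the first large step read at a single place, so among these three compounds the large change follows that group and not the hydroxy-nitrophenyl isomer. Nothing in hand explains either result.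

The large step joins two changes, the benzyl link and the sulfonyl, and a (4-bromobenzyl)sulfanyl group on the same carbon would be needed to separate them. From the compounds shown here alone, whether the hydroxy and nitro groups matter at all also stays open, since the isomer pair only moves them around the ring, and a methoxy group in place of the hydroxy or an amine in place of the nitro would address this.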